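The compounds below may be only part of what the source reports. "The series", "measured", "known", "first", "only" and "open" are said of these compounds alone.

Compound 1 `Cc1cc(C)c2cc(C(=O)NC3CCCCC3)[nH]c2c1` carries an amide-linked cyclohexyl group on an indole core. In a physicochemical assay for solubility, measured as thermodynamic solubility, with a stated time of 24 h, at pH 6.8 (a lower number here means a less soluble compound, a higher number a more soluble compound), compound 1 gives < 4000 nM, which is a limit of the measurement rather than a number. Compound 2 `Cc1cc(C)c2cc(C(=O)N[C@@H]3CCCC[C@@H]3C)[nH]c2c1` differs from compound 1 by methyl in place of hydrogen on a saturated ring carbon. In this assay compound 2 gives < 4000 nM, again only a limit. The step that the two limits leave unreadable from compound 1 to compound 2 therefore cannot be sized, since both ends sit at the limit.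

Compound 3 `CC1CCC(NC(=O)c2cc3c(Cl)cc(Cl)cc3[nH]2)CC1` has a different core; how the two cores differ is not broken down here. In this assay compound 3 gives < 4000 nM, which is also a limit. All three measured compounds share (the limit of < 4000 nM in this assay, at which 3 of the 3 values shown sit), so none of them has been resolved to a number.

Compound 4 `CC1(C)CCC(NC(=O)c2cc3c(Cl)cc(Cl)cc3[nH]2)CC1`, not yet measured, differs from compound 3 by methyl in place of hydrogen on a saturated ring carbon. For the measured compounds named here, this is the same kind of change as the one from compound 1 to compound 2, but the place is not the same: in compound 2 the methyl sits next to the ring atom that bears a large group, whereas in compound 4 it sits three ring bonds from the ring atom that bears a large group.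

Given that every value so far sits at the limit, the step from compound 3 to compound 4 is expected to be about a step that the limit leaves unreadable from compound 3 to compound 4, which cannot be read from the earlier, unreadable step. Compound 4 is estimated to give 1500 nM in this assay, with a likely range from 300 nM to 4000 nM, and it is expected most likely to be reported only as a limit as well.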

Compound 4, solubility: < 4000 nM
Compound 4: a limit, no number (the forecaster's own chance of this, stated with the estimate: 80%); the middle value is on the limit's open side.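

In this assay compound 4 gives < 4000 nM, which is a limit and not a number. Compound 3 is also known only as a limit, so the step between compound 3 and compound 4 cannot be read. All four compounds stop at the same point: the limit of < 4000 nM in this assay, at which 4 of the 4 values shown sit. The compounds shown leave open how soluble each one actually is, and whether adding a methyl changes that at either ring place.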